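A Difluorophenyl Swap on a Sulfonyl Sulfur

A few compounds are considered here, and "the series" means these few. Any claim that something is new, unique, unknown or untested is made for them only; others in the source may bear on it.

In a functional assay on MDA-MB-231 cells (Homo sapiens) for inhibition, with a stated time of 5 h (a lower number here means a stronger inhibitor, a higher number a weaker inhibitor), compound 1 `COc1cc2c(Oc3ccc(NS(=O)(=O)c4ccccc4C(F)(F)F)cc3F)ccnc2cc1OCCCN1CCN(C)CC1` gives 158 nM, and compound 2 `COc1cc2c(Oc3ccc(NS(=O)(=O)c4cc(F)ccc4F)cc3F)ccnc2cc1OCCCN1CCN(C)CC1` gives 158 nM, level with it. Compound 3 `COc1cc2c(Oc3ccc(NS(=O)(=O)c4c(F)cccc4F)cc3F)ccnc2cc1OCCCN1CCN(C)CC1` has the same atoms as compound 2, joined differently, with 2,6-difluorophenyl in place of 2,5-difluorophenyl on a sulfonyl sulfur. Among the measured compounds shown here, only one measured step changes the group at this place, no change at the digits printed from compound 1 to compound 2 (within the scatter), and it stayed within the scatter. That is thin evidence, but it gives no reason to expect a large shift. The step of a 1.1-fold lower number from compound 2 to compound 3 (0.02 log units; within the scatter) is therefore expected to stay within the scatter, with no clear direction. The estimated value for compound 3 is 150 nM, with an expected range from 50 nM to 450 nM.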

Compound 3, half-maximal inhibitory concentration: 156 nM
Estimate against measurement, compound 3: 1.0-fold (0.02 log units) below, within the range that was stated.
By their numbers in this assay, from the lowest: compounds 3, 1 and 2 (each within the scatter of the next).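

Moving one fluorine, so that 2,6-difluorophenyl replaces 2,5-difluorophenyl on the sulfonyl sulfur, gives a 1.0-fold lower number from compound 2 to compound 3 (0.01 log units; within the scatter) in this assay, so rearranging the same atoms on this ring leaves the number level. Replacing 2-(trifluoromethyl)phenyl with 2,6-difluorophenyl gives a 1.0-fold lower number from compound 1 to compound 3 (0.01 log units; within the scatter) as well, which places all three substituted phenyl groups within the scatter of one another. No measurement shown here accounts for this flat result.

Still open, going by these compounds, is whether the position stays as flat with a group of a different kind, such as an amine or a carboxylic acid, in place of the phenyl ring.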